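Piperazine amide series: aryl change on the ring nitrogen

The source may report more compounds than this note shows. Statements on the series, on what has been measured and on what is new or still open speak of the compounds shown alone.

Compound 1 `Cc1nc(-c2ccccc2)c(C(=O)N2CCN(c3cccc(C#N)c3)CC2)o1` is the reference point. In a functional assay on HL-60 cells (Homo sapiens) for inhibition, read by MTT assay, with a stated time of 72 h (on this read-out lower numbers stand for stronger inhibition and higher numbers for weaker inhibition), compound 1 gives 39.6 nM. Compound 2 `COc1cc(OC)cc(N2CCN(C(=O)c3oc(C)nc3-c3ccc(F)cc3)CC2)c1` gives 38.5 nM, and compound 3 `Cc1ccc(C)c(N2CCN(C(=O)c3oc(C)nc3-c3cccc(F)c3)CC2)c1` gives 204 nM. Among these three numbers compound 1 stands second highest: its number and that of compound 2 lie within the scatter of each other, whereas compound 3 gives a higher number, beyond the scatter. Within the data shown here, no pair of measured compounds differs in only one place, so no single-change step is available from the measured set.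

Compound 4 `Cc1nc(-c2ccccc2)c(C(=O)N2CCN(c3ccccc3C(F)(F)F)CC2)o1` differs from compound 1 in one place: 2-(trifluoromethyl)phenyl in place of 3-cyanophenyl on an amine nitrogen in a ring. Nothing measured isolates this exact exchange; compound 3, with a different aryl on the ring nitrogen and a different aryl elsewhere, gives the highest number, but the two changes cannot be separated. A small rise in the number, likely within the scatter, is expected for the step of a 1.8-fold higher number from compound 1 to compound 4 (0.25 log units; within the scatter). Compound 4 is estimated at 70 nM, with a range from 25 nM to 250 nM.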

Compound 4, half-maximal inhibitory concentration: 120 nM
Beside the measured number, compound 4's estimate is 1.7-fold (0.23 log units) below it; low and high end bracket the measured number.
By their numbers in this assay, from the lowest: compounds 2 and 1 (each within the scatter of the next); then compounds 4 and 3 (each within the scatter of the next).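

Among these compounds, this is the first single-change step: in this assay, the exchange of 3-cyanophenyl for 2-(trifluoromethyl)phenyl on the amine nitrogen in the ring gives a 3.0-fold higher number from compound 1 to compound 4 (0.48 log units; beyond the scatter). The rest of the structure is held constant, so the aryl group on this nitrogen is shown to affect the read-out, which compounds 1, 2 and 3 could not show because they differ in more than one place. Nothing measured here accounts for the size of this step.

Among the compounds shown here, the single exchange removes the nitrile and introduces the trifluoromethyl group, and the step cannot assign the rise in the number to either one. A plain phenyl on the ring nitrogen, on the core of compound 1, would give a common comparison for both groups.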